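Removing the Bromo Group from Compound 1

This account rests on a few compounds, and the source may have more. Where it says the series, first, only, none or still open, it means among the compounds named here.

In a functional assay on RAW264.7 cells (Mus musculus) for inhibition (on this read-out higher numbers stand for weaker inhibition and lower numbers for stronger inhibition), compound 1 `COc1cccc(O)c1C(=O)/C=C/c1cccc(Br)c1` gives 7800 nM. Two structurally different compounds offer some context: compound 2 `CC(C)=CCC/C(C)=C/Cc1c(O)c2c(c(/C=C/C(=O)c3ccc(O)c(O)c3)c1O)OC(C)(C)C=C2` gives 9500 nM, and compound 3 `COc1cc(C(=O)/C=C/c2cc(OC)c(OC)c(OC)c2)ccc1O` gives 4190 nM. Compound 1 lies within the usual scatter of both. Compound 4 `COc1cccc(O)c1C(=O)/C=C/c1ccccc1` keeps the core of compound 1 but carries hydrogen in place of bromo on an aromatic carbon, meta to a large group (hydrogen in place of bromo on an aromatic carbon). Among the compounds with values here, no two measured compounds differ in only one place, so the data show nothing directly about a change like this one. The estimated step of a 1.1-fold higher number from compound 1 to compound 4 (0.04 log units; within the scatter) is expected to stay within the scatter, with no firm direction. For compound 4 the expected value is 8500 nM, with an estimated range from 3000 nM to 22000 nM.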

Compound 4, half-maximal inhibitory concentration: 9600 nM
Compound 4: the middle estimate sits 1.1-fold (0.05 log units) below what was measured; measured number inside the range.
By their numbers in this assay, from the lowest: compounds 3, 1, 2 and 4 (each within the scatter of the next, the first and the last beyond it).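

In this assay, within the data shown here, hydrogen in place of bromo on this aromatic carbon gives a 1.2-fold higher number from compound 1 to compound 4 (0.09 log units; within the scatter), the first direct comparison at this position. The two compounds cannot be told apart here, so the bromo group is not needed to keep this level of inhibition. No supporting measurement bears on this result. On these data alone, whether an amine or a carboxylic acid on this same carbon would move the number beyond the scatter remains open. So does whether bromo elsewhere on this ring would behave the same way.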